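Two halogen swaps on the sulfonyl aryl ring

The source may report more compounds than this note shows. Statements on the series, on what has been measured and on what is new or still open speak of the compounds shown alone.

Measured so far:
- compound 1, `Cc1cn(Cc2ccc(Cl)cc2Cl)c2c(-c3nnc(NS(=O)(=O)c4cc(F)c(F)cc4F)o3)cc(F)cc12`: 3%
- compound 2, `Cc1cn(Cc2ccc(Cl)cc2Cl)c2c(-c3nnc(NS(=O)(=O)c4ccc(Cl)c(Cl)c4)o3)cc(F)cc12`: 3%

In an assay on isolated protein with thromboxane A2 receptor (Homo sapiens) as the target, read by FLIPR, tested at 0.1 uM (on this read-out higher numbers stand for a stronger effect at the one concentration tested and lower numbers for a weaker effect), compound 2 gives 3%, level with compound 1. Among the compounds with values here, the one measured step, no change at the digits printed from compound 1 to compound 2 (within the scatter), stayed within the scatter. Compound 3, `Cc1cn(Cc2ccc(Cl)cc2Cl)c2c(-c3nnc(NS(=O)(=O)c4ccc(F)c(F)c4)o3)cc(F)cc12`, differs from compound 2 by 3,4-difluorophenyl in place of 3,4-dichlorophenyl on a sulfonyl sulfur. That earlier exchange of one halogenated phenyl for another on the sulfonyl sulfur moved nothing, so the expected step in this assay is no change at the digits printed from compound 2 to compound 3 (within the scatter), none beyond the scatter. Compound 3 is therefore estimated at 3%, within a range from -5% to 12%.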

Compound 3, a percentage reported as activity, at one concentration (the size of the read-out at that concentration, not a potency): -5%
Estimate against measurement, compound 3: 8 percentage points above; the range from low to high includes it.
By their numbers in this assay, from the lowest: compounds 3, 1 and 2 (each within the scatter of the next).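

In this assay, 3,4-difluorophenyl in place of 3,4-dichlorophenyl on the sulfonyl sulfur gives a number 8 percentage points lower from compound 2 to compound 3 (within the scatter), and hydrogen in place of one fluoro on the aromatic ring gives a number 8 percentage points lower from compound 1 to compound 3 (within the scatter). So neither the kind of halogen nor the number of fluoro groups tried on this ring separates the three compounds at the one concentration tested. No other measurement is available to help interpret this result. Still open, from the compounds shown here alone, is whether an amine or a carboxylic acid on this ring, or an alkyl chain replacing the ring entirely, would read differently.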